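Extending the Ethyl Arm of Compound 3 with Dimethylamino

The compounds below may be only part of what the source reports. "The series", "measured", "known", "first", "only" and "open" are said of these compounds alone.

Compound 3 `CCN(Cc1ccccc1)c1ccc(C(=O)N2CCc3ccc(OS(N)(=O)=O)cc3C2)cc1` carries a benzyl(ethyl)amino group on an aromatic carbon of the shared core. Going by the values given here, in an assay on HEK293 cells for inhibition of Steryl-sulfatase (Homo sapiens), tested at 0.1 uM (a lower number here means a weaker effect, a higher number a stronger effect of the compound at the concentration tested), compound 3 gives 66.9%, the highest of the three numbers known. Compound 1 `CCN(Cc1cccnc1)c1ccc(C(=O)N2CCc3ccc(OS(N)(=O)=O)cc3C2)cc1` gives 35.7% in this assay, and compound 2 `NS(=O)(=O)Oc1ccc2c(c1)CN(C(=O)c1ccc(N3CCCCC3)cc1)CC2` gives 11.5%. The steps connecting them show that the group on this nitrogen matters: a number 31.2 percentage points higher from compound 1 to compound 3 (beyond the scatter), and a number 55.4 percentage points higher from compound 2 to compound 3 (beyond the scatter); in the other direction, a number 24.2 percentage points lower from compound 1 to compound 2 (beyond the scatter).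

Compound 4 `CN(C)CCN(Cc1ccccc1)c1ccc(C(=O)N2CCc3ccc(OS(N)(=O)=O)cc3C2)cc1` differs from compound 3 in one place: dimethylamino in place of hydrogen on a saturated chain carbon, two bonds along the chain from a nitrogen on an aromatic ring. The benzyl group that distinguishes compound 3 from compound 1 is kept, and only the ethyl grows into 2-(dimethylamino)ethyl. Among the compounds with values here, no measured step bears directly on this change; the two steps into compound 3 alter the groups on the nitrogen itself, not the ethyl. Both of those steps were large, so this part of the molecule has shown itself sensitive, and a new group two bonds along the chain from the nitrogen on the aromatic ring could shift the number either way. The expectation for compound 4 is a modest loss at most, with the step of a number 11.9 percentage points lower from compound 3 to compound 4 (beyond the scatter). Compound 4 is therefore estimated at 55%, between 30% and 75%.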

Compound 4, a percentage reported as inhibition, at one concentration (the size of the read-out at that concentration, not a potency): 13.9%
Beside the measured number, compound 4's estimate is 41.1 percentage points above it, and the stated range ends above it.
By their numbers in this assay, from the lowest: compounds 2 and 4 (each within the scatter of the next); then compound 1; then compound 3.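

In this assay, going by these compounds alone, the growth of ethyl into 2-(dimethylamino)ethyl gives a number 53 percentage points lower from compound 3 to compound 4 (beyond the scatter) even though the benzyl group stays in place, so the ethyl arm is itself a sensitive part of the molecule, which the earlier steps, all made on other groups on this nitrogen, could not show. The benzyl group, linked to a number 31.2 percentage points higher from compound 1 to compound 3 (beyond the scatter) in the earlier series, is present in compound 4 as well, so in this series it does not secure a high number on its own. No measurement available here accounts for the loss.

From the compounds shown here alone, what remains open is whether the loss follows the terminal dimethylamino group or the longer chain itself, a question that a propyl, butyl or 2-methoxyethyl arm on the same nitrogen, or a 2-(morpholin-4-yl)ethyl arm, would help to settle. Also open, going by these compounds, is whether a 2-(dimethylamino)ethyl arm would have the same effect with pyridin-3-yl in place of phenyl, as in compound 1, or whether a shorter amine such as aminomethyl would be tolerated at this place.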